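This account rests on a few compounds, and the source may have more. Where it says the series, first, only, none or still open, it means among the compounds named here.

Of the compounds shown here, three have so far been measured in a functional assay on RAW264.7 cells (Mus musculus) for inhibition, read by microscopy and resazurin assay, with a stated time of 72 h; on this read-out lower numbers stand for stronger inhibition and higher numbers for weaker inhibition. Compound 1 `COC(=O)[C@H](CC(C)C)NC(=O)c1ccc(/C=C2\SC(=O)N(CC(=O)NOCc3ccccc3)C2=O)cc1` and compound 2 `COC(=O)[C@@H](NC(=O)c1ccc(/C=C2\SC(=O)N(CC(=O)NOCc3ccccc3)C2=O)cc1)C(C)C` share one core and differ in a single place: isobutyl in place of isopropyl on a saturated chain carbon bound to an amide-type nitrogen and a carbonyl carbon. Compound 3 `C=CCONC(=O)Cn1cc(C(=O)N[C@@H](C)C(=O)N[C@H](C(=O)O)C(C)C)c2ccccc21` is built on another core, and the difference between the core of compound 3 and the core of compound 2 is not broken down here.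

In this assay compound 1 gives only a limit, > 128000 nM. In this assay compound 2 likewise gives only a limit, > 128000 nM. In this assay compound 3 also reaches only a limit, > 128000 nM. The step that the two limits leave unreadable from compound 2 to compound 1 therefore cannot be sized because of the limit of > 128000 nM in this assay, at which 3 of the 3 values shown sit.

Compound 4 `C=CCONC(=O)Cn1cc(C(=O)N[C@@H](C)C(=O)N[C@@H](CC(C)C)C(=O)O)c2ccccc21` has not yet been measured in this assay. Among the compounds with values here, it differs from compound 3 by isobutyl in place of isopropyl on a saturated chain carbon bound to an amide-type nitrogen and a carbonyl carbon, which is the same change as the one from compound 2 to compound 1, made at the same place, a saturated chain carbon bound to an amide-type nitrogen and a carbonyl carbon. Since that change left both compound 1 and compound 2 at the limit, and compound 3 itself sits at the limit, the same change on the core of compound 3 is expected to leave compound 4 at the limit as well. The step from compound 3 to compound 4 is expected to be a step that the limit leaves unreadable from compound 3 to compound 4, which only means that no readable number is expected. Compound 4 is accordingly estimated at 200000 nM, somewhere between 60000 nM and 700000 nM, most probably reported as a limit rather than a number.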

Compound 4, half-maximal inhibitory concentration: > 128000 nM
Compound 4 was reported as a limit; the forecaster's own chance of this, stated with the estimate: 85%; the middle value is on the limit's open side.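

In this assay compound 4 gives only a limit, > 128000 nM. No size can be read for the change from compound 3 to compound 4, because neither compound gives a number: the limit of > 128000 nM in this assay, at which 4 of the 4 values shown sit.

The compounds shown leave open whether isobutyl in place of isopropyl alters inhibition at all on either core, and what structure would give a readable number in this assay.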